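The source may hold more compounds than are shown below. What is called first, only, known or untested is meant among the compounds shown, and "the series" means these compounds.

Compounds measured so far in an in vitro assay on SH-EP1 cells for displacement of a labelled ligand from Neuronal acetylcholine receptor; alpha4/beta2 (Homo sapiens); on this read-out higher numbers stand for weaker inhibition and lower numbers for stronger inhibition:

Compound 1 `Fc1ccc(C2=CC3CNCC(C2)C3)cn1`: 0.4 nM
Compound 2 `CN1CC2C=C(c3ccc(F)nc3)CC(C2)C1`: 18 nM
Compound 3 `Fc1ccc(Oc2cncc(C3=CC4CNCC(C3)C4)c2)cc1`: 0.6 nM

Compound 1 gives the lowest number of the three, though compound 3 sits within the scatter of it; only compound 2 lies clearly apart, and that step, a 45-fold higher number from compound 1 to compound 2 (1.65 log units; beyond the scatter), came from methyl in place of hydrogen on an amine nitrogen in a ring. Compound 4 `C1=C(c2cccnc2)CC2CNCC1C2` differs from compound 1 in another place: hydrogen in place of fluoro on an aromatic carbon. Within the data shown here, no measured step touches this position, so nothing among the three compounds bears directly on it. With a single fluorine leaving and no change elsewhere, the step of a 1.8-fold higher number from compound 1 to compound 4 (0.24 log units; within the scatter) is expected to stay within the scatter. Compound 4 is therefore estimated at 0.7 nM, with a range of 0.25 nM to 2.5 nM.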

Compound 4, inhibition constant: 0.2 nM
Compound 4: the middle estimate sits 3.5-fold (0.54 log units) above what was measured; measured number outside the range, below it.
By their numbers in this assay, from the lowest: compounds 4, 1 and 3 (each within the scatter of the next, the first and the last beyond it); then compound 2.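

In this assay, among these compounds, hydrogen in place of fluoro on an aromatic carbon next to the ring nitrogen gives a 2.0-fold lower number from compound 1 to compound 4 (0.30 log units; within the scatter), the first measured step at this position. The fluoro group is therefore not required for the low number of compound 1, and the two compounds cannot be told apart here. No available evidence accounts for this result. The compounds shown carry only fluoro or hydrogen at this position, so it remains open how a chloro, methoxy or amino group would fare there. Also open, from the compounds shown here alone, is whether hydrogen in place of fluoro would give a similar result in compound 2, which carries the methyl group on the ring nitrogen.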